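From Nitro to Chloro on the Aryl Ring

The compounds below may be only part of what the source reports. "The series", "measured", "known", "first", "only" and "open" are said of these compounds alone.

Compound 2 `CC1=CC[C@@H]([C@@](C)(O)CCCC(C)(C)NC(=S)N/N=C\c2ccccc2[N+](=O)[O-])CC1` reaches only a limit of > 100000 nM in a functional assay on NCI-H460 cells (Homo sapiens) for cytotoxicity, read by sulforhodamine B assay; a higher number here means a weaker inhibitor of growth, a lower number a stronger inhibitor of growth. Among the measured compounds shown here, compound 1 `CC1=CC[C@@H]([C@@](C)(O)CCCC(C)(C)NC(=S)N/N=C\c2ccc(O)cc2)CC1` gives 20700 nM in this assay, so the one measured step is an at least 4.8-fold higher number from compound 1 to compound 2 (0.68 log units; beyond the scatter), which runs up to the limit of > 100000 nM in this assay, at which 1 of the 2 values shown sits. Compound 3 `CC1=CC[C@@H]([C@@](C)(O)CCCC(C)(C)NC(=S)N/N=C\c2ccccc2Cl)CC1` carries chloro in place of nitro on an aromatic carbon. For the measured compounds named here, no measured step covers this exact exchange, and the step from compound 1 to compound 2 shows only that the 2-nitrophenyl compound sits at the limit. Compound 3 is therefore expected to land near 60000 nM in this assay, between 20000 nM and 200000 nM, an expected step of an at least 1.6-fold lower number from compound 2 to compound 3 (0.22 log units; that floor lies within the scatter).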

Compound 3, concentration for total growth inhibition: > 100000 nM
Compound 3: a limit, no number; the forecaster's own chance of this, stated with the estimate: 40%; middle value at least 1.6-fold (0.22 log units) away from the limit.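

Among the compounds shown here, compound 3 gives only a limit in this assay, not a number, so nitro is not the only group on this aromatic carbon that ends there, and the step from compound 2 cannot be read. Against the 4-hydroxyphenyl group, the 2-chlorophenyl group gives an at least 4.8-fold higher number from compound 1 to compound 3 (0.68 log units; beyond the scatter). Nitro and chloro on this carbon now end at the same place: the limit of > 100000 nM in this assay, at which 2 of the 3 values shown sit.

On these data alone, whether nitro and chloro differ at all stays open. So does whether an amine or a carboxylic acid on this aromatic carbon would give a number rather than a limit.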